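One Halogen Swap, Two Cores, One Expected Step

The compounds below may be only part of what the source reports. "The series", "measured", "known", "first", "only" and "open" are said of these compounds alone.

Measured so far in a functional assay on DU-145 cells (Homo sapiens) for cytotoxicity, read by MTT assay, with a stated time of 24 h; on this read-out higher numbers stand for weaker inhibition and lower numbers for stronger inhibition:
Compound 1 `COc1ccc(/C=C2\CN(Cc3cn(Cc4ccc(F)cc4)nn3)C/C(=C\c3ccc(OC)cc3)C2=O)cc1` gives 59400 nM.
Compound 2 `O=C1/C(=C/c2ccccc2F)CN(Cc2cn(Cc3ccccc3Cl)nn2)C/C1=C\c1ccccc1F` gives 7500 nM.
Compound 3 `COc1ccc(/C=C2\CN(Cc3cn(Cc4ccccc4Cl)nn3)C/C(=C\c3ccc(OC)cc3)C2=O)cc1` gives 17800 nM.

Compound 1 and compound 3 share one core and differ in a single place: 4-fluorophenyl in place of 2-chlorophenyl on a saturated chain carbon bound to an aromatic nitrogen. That exchange produced a 3.3-fold higher number from compound 3 to compound 1 (0.52 log units; beyond the scatter). Compound 2 is built on a different core; how its core differs from that of compound 3 is not broken down here. Its number is the lowest of the three, with compound 3 nearest and compound 1 furthest away.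

Compound 4 `O=C1/C(=C/c2ccccc2F)CN(Cc2cn(Cc3ccc(F)cc3)nn2)C/C1=C\c1ccccc1F` has not yet been measured. It stands to compound 2 as compound 1 stands to compound 3: 4-fluorophenyl in place of 2-chlorophenyl on a saturated chain carbon bound to an aromatic nitrogen. Because a 3.3-fold higher number from compound 3 to compound 1 (0.52 log units; beyond the scatter) weakened inhibition when made on the other core, the same kind of step is expected here, though a single example on a different core leaves room for a smaller or larger move. The step from compound 2 to compound 4 in this assay is estimated at a 2.9-fold higher number from compound 2 to compound 4 (0.47 log units; beyond the scatter). Compound 4 is therefore expected to give about 22000 nM, most likely falling between 8000 nM and 60000 nM.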

Compound 4, half-maximal inhibitory concentration: 8700 nM
Estimate against measurement, compound 4: 2.5-fold (0.40 log units) above, within the range that was stated.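

The exchange of 2-chlorobenzyl for 4-fluorobenzyl gives, in this assay, a 1.2-fold higher number from compound 2 to compound 4 (0.06 log units; within the scatter), a step too small to tell apart from repeat measurements. Set beside the earlier step, the same exchange does not carry over in size from one core to the other: the same change on two cores in this assay, a 3.3-fold higher number (0.52 log units; beyond the scatter) from compound 3 to compound 1 and a 1.2-fold higher number (0.06 log units; within the scatter) from compound 2 to compound 4, 2.9-fold (0.46 log units) apart, beyond the scatter of two such steps These two pairs show that a step seen on one core need not repeat on another in this series, but they do not show what in the cores sets the two steps apart, or how the exchange would behave on a third core.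

The compounds shown leave open whether the halogen itself or the place it occupies on the ring matters, since only two groups are compared on each core. Plain phenyl or 4-chlorophenyl, on a saturated chain carbon bound to an aromatic nitrogen and placed on both cores, could help to separate those two questions.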